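Ester to acid on the peroxide series: next step

The compounds below may be only part of what the source reports. "The series", "measured", "known", "first", "only" and "open" are said of these compounds alone.

Measured so far:
- compound 1, `CCCC(CC)CC(C)C[C@]1(CC)C[C@H](CC)[C@H](CC(=O)OC)OO1`: 24400 nM in a functional assay on MDA-MB-231 cells (Homo sapiens) for cytotoxicity; on this read-out higher numbers stand for weaker inhibition and lower numbers for stronger inhibition
- compound 2, `CCCCC(CC)CC(C)C[C@]1(CC)C[C@H](CC)[C@H](CC(=O)OC)OO1`: 18400 nM in this assay

Compound 2 has the lowest of the two numbers in this assay, but its neighbour compound 1 sits within the scatter, so no order between the two can be read. Within the data shown here, the single measured step, a 1.3-fold lower number from compound 1 to compound 2 (0.12 log units; within the scatter), is the only comparison available, and it concerns a methyl added on the saturated chain, far from the ester.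

Compound 3, `CCCCC(CC)CC(C)C[C@]1(CC)C[C@H](CC)[C@H](CC(=O)O)OO1`, is not yet measured. It differs from compound 2 by hydrogen in place of methyl on an oxygen next to a carbonyl group. Among the measured compounds shown here, no measured step touches the ester, so the step from compound 1 to compound 2 does not bear on it, and nothing measured here tells what a change at the ester does in this assay. The working expectation is therefore a number close to that of compound 2, with no step beyond the scatter, and a wide range to allow for the ester being altered. The step expected is a 1.4-fold higher number from compound 2 to compound 3 (0.13 log units; within the scatter). For compound 3 the estimate in this assay is 25000 nM, with a range from 8000 nM to 80000 nM.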

Compound 3, half-maximal inhibitory concentration: 9000 nM
Compound 3: the middle estimate sits 2.8-fold (0.44 log units) above what was measured; low and high end bracket the measured number.
By their numbers in this assay, from the lowest: compound 3; then compounds 2 and 1 (each within the scatter of the next).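

The ester position now has a measured step of its own: in this assay, methoxycarbonyl to carboxy gives a 2.0-fold lower number from compound 2 to compound 3 (0.31 log units; beyond the scatter), a modest change but one that clears the scatter. The only earlier comparison, the methyl added on the saturated chain, gave a 1.3-fold lower number from compound 1 to compound 2 (0.12 log units; within the scatter) and so showed no readable change, which leaves hydrogen in place of methyl on an oxygen next to a carbonyl group as the only single change shown here that moves the number beyond the scatter. No measurement at hand accounts for this step.

Going by these compounds, the carboxy group appears here only on the chain of compound 2, so it remains open whether the same change would give a similar step on the shorter chain of compound 1. On these data alone, it is also open how other groups in place of methoxycarbonyl, such as an ethyl ester, a primary amide or a tetrazole, would compare with compound 2 and compound 3 in this assay.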